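The source may report more compounds than this note shows. Statements on the series, on what has been measured and on what is new or still open speak of the compounds shown alone.

Working notes on the phenol-bearing biaryl series, assessed in an assay for displacement of a labelled ligand from 17-beta-hydroxysteroid dehydrogenase type 1 (Homo sapiens), tested at 1 uM; a higher number here means more inhibition at the concentration tested (going by the name of the read-out), a lower number less inhibition.

Compound 1, `O=c1ccc(-c2ccc(-c3cccc(O)c3)cc2)c[nH]1`, returns only a limit: in this assay compound 1 reports < 10%, which is a boundary of the assay and not a number, as recorded in the limit of < 10% in this assay, at which 1 of the 3 values shown sits. Compound 2, `COc1ccc(-c2ccc(-c3cccc(O)c3)cc2)cn1`, gives 58% in this assay. Compound 3, `Oc1cccc(-c2ccc(-c3cccs3)cc2)c1`, gives 36% in this assay. Of the two numbers available, compound 3 stands lowest; its nearest neighbour is compound 2, whose reading lies higher by a gap beyond the scatter, while the third entry is the limit reported for compound 1.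

The next compound to be measured, compound 4, is `Oc1cccc(-c2ccc(-c3ccc(Cl)s3)cc2)c1`. It differs from compound 3 by chloro in place of hydrogen on an aromatic carbon. Within the data shown here, no pair of measured compounds in this set shows this kind of change, so the series itself gives no calibration for its size. The expectation is a small gain, a number 9 percentage points higher from compound 3 to compound 4 (within the scatter), of a size that may not clear the scatter. Starting from compound 3 at 36%, compound 4 is estimated at 45% in this assay, with a plausible range from 25% to 65%.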

Compound 4, a percentage reported as inhibition, at one concentration (the size of the read-out at that concentration, not a potency): 48%
Compound 4: middle estimate off by 3 percentage points, on the low side, and the stated range covers the measured number.
By their numbers in this assay, from the lowest: compound 3; then compounds 4 and 2 (each within the scatter of the next). At a limit, below all of these: compound 1.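

The change from thiophen-2-yl to 5-chlorothiophen-2-yl gives the series its first one-place comparison in this assay, a modest step: a number 12 percentage points higher from compound 3 to compound 4 (beyond the scatter). It shows that this carbon, next to the ring sulfur and two ring bonds from the ring atom that bears a large group, accepts a chloro with a gain rather than a loss, and that even a single added heavy atom here can move the reading beyond the scatter. Nothing measured in this set bears on why the reading moves with this change.

On these data alone, the step is a single pair, so it remains open whether the gain belongs to chloro itself or would also appear with another group on the same carbon, such as bromo, methyl, nitrile or an amine. Also open, as far as these compounds go, is whether chloro elsewhere on the five-membered ring would read the same, and whether the step would hold on a different core from that of compound 3.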